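Trading methylsulfonyl for methyl in a solubility series

This account rests on a few compounds, and the source may have more. Where it says the series, first, only, none or still open, it means among the compounds named here.

Compound 1 `NCc1csc(NC(=O)c2ccccn2)n1`: > 100 ug/mL, a limit of the assay
Compound 2 `CC(C)(C)c1cc(C(=O)Nc2nc(CNS(C)(=O)=O)cs2)n(Cc2ccccc2)n1`: 3.1 ug/mL
Compound 3 `NCc1csc(NC(=O)c2ccn[nH]2)n1`: > 100 ug/mL, a limit of the assay

Among the measured compounds shown here, in a physicochemical assay for solubility, read by nephelometry, measured as kinetic solubility, at pH 2.0 (a higher number here means a more soluble compound, a lower number a less soluble compound), compound 2, at 3.1 ug/mL, holds the only actual number of the three. The results of compound 1 and compound 3 are limits of the assay. Compound 4 `CNCc1csc(NC(=O)c2cc(C(C)(C)C)nn2Cc2ccccc2)n1` has not yet been measured. It differs from compound 2 by one change, methyl in place of methylsulfonyl on an amine nitrogen. For the measured compounds named here, no measured pair shows this change, so the expectation leans on (the limit of > 100 ug/mL in this assay, at which 2 of the 3 values shown sit). A rise beyond the usual scatter is expected in this assay, an estimated 16-fold higher number from compound 2 to compound 4 (1.21 log units; beyond the scatter). For compound 4 the estimated value is 50 ug/mL, with an expected range of 12 ug/mL to 100 ug/mL.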

Compound 4, solubility: 25 ug/mL
The estimate for compound 4 lay 2.0-fold (0.30 log units) above the measured number; the measured number falls inside the stated range.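

Among the compounds shown here, replacing methylsulfonyl with methyl on the amine nitrogen gives the first readable step in this assay, an 8.1-fold higher number from compound 2 to compound 4 (0.91 log units; beyond the scatter), since no earlier pair differed in one place only. The step shows that this position, with the rest of the structure held constant, can shift the reading beyond the scatter. Compound 4 still reads as an actual number rather than a limit: the limit of > 100 ug/mL in this assay, at which 2 of the 4 values shown sit.

Going by these compounds, it remains open how an ethyl or acetyl group on the same amine nitrogen would read. The compounds shown also leave open whether this step would hold on a different core.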